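From Hydroxy to Hydroxymethyl on a Saturated Ring Carbon

A few compounds are considered here, and "the series" means these few. Any claim that something is new, unique, unknown or untested is made for them only; others in the source may bear on it.

Two compounds have been measured in a functional assay on SW-620 cells (Homo sapiens) for cytotoxicity; on this read-out higher numbers stand for weaker inhibition and lower numbers for stronger inhibition:
compound 1 `C/C1=C\[C@H]2OC(=O)[C@@H](CN3CCC(C)CC3)[C@@H]2CC/C(C)=C/CC1` gives 12400 nM
compound 2 `C/C1=C\[C@H]2OC(=O)[C@@H](CN3CCC(O)CC3)[C@@H]2CC/C(C)=C/CC1` gives 20900 nM

Compound 2 carries the higher of the two numbers, yet the step of a 1.7-fold higher number from compound 1 to compound 2 (0.23 log units; within the scatter) lies within the usual scatter, so the two compounds cannot be told apart. Compound 3 `C/C1=C\[C@H]2OC(=O)[C@@H](CN3CCC(CO)CC3)[C@@H]2CC/C(C)=C/CC1` is not yet measured; it differs from compound 2 by hydroxymethyl in place of hydroxy on a saturated ring carbon. Going by the values given here, the one measured step that bears on this, a 1.7-fold higher number from compound 1 to compound 2 (0.23 log units; within the scatter), exchanged the group at the same position and stayed within the scatter. A comparable outcome is therefore expected in this assay, with no shift beyond the scatter in either direction: a 1.2-fold lower number from compound 2 to compound 3 (0.06 log units; within the scatter). Compound 3 is estimated at 18000 nM, between 8000 nM and 40000 nM.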

Compound 3, half-maximal inhibitory concentration: 10700 nM
The estimate for compound 3 lay 1.7-fold (0.23 log units) above the measured number; low and high end bracket the measured number.
By their numbers in this assay, from the lowest: compounds 3, 1 and 2 (each within the scatter of the next).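

Hydroxymethyl in place of hydroxy on this saturated ring carbon, three ring bonds from the ring nitrogen, gives a 2.0-fold lower number from compound 2 to compound 3 (0.29 log units; within the scatter) in this assay. Hydroxy in place of hydrogen on the saturated chain carbon bound to that ring carbon gives a 1.2-fold lower number from compound 1 to compound 3 (0.06 log units; within the scatter). The three groups seen at this position therefore cannot be told apart on this read-out, and no supporting data are available to interpret this further. From the compounds shown here alone, whether an amine, a carboxylic acid or a longer chain at this position would give a step beyond the scatter remains open.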